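Core ring fluorination next to the anilino group

The compounds below may be only part of what the source reports. "The series", "measured", "known", "first", "only" and "open" are said of these compounds alone.

For the measured compounds named here, compound 1 `NC(=O)c1c(Nc2ccc(I)cc2F)cc(F)cc1Oc1cccc(NS(N)(=O)=O)c1` gives 180 nM in a functional assay on HCT-116 cells (Homo sapiens) for antiproliferative activity (a higher number here means a weaker inhibitor, a lower number a stronger inhibitor), the second highest of the three numbers measured so far. Compound 2 `NC(=O)c1c(Nc2ccc(I)cc2F)cc(F)cc1Oc1cccc(NS(N)(=O)=O)c1Cl` gives 87 nM in this assay, and compound 3 `CC(NS(N)(=O)=O)c1cccc(Oc2cc(F)cc(Nc3ccc(I)cc3F)c2C(N)=O)c1` gives 731 nM. The step of a 2.1-fold lower number from compound 1 to compound 2 (0.32 log units; beyond the scatter) and the step of a 4.1-fold higher number from compound 1 to compound 3 (0.61 log units; beyond the scatter) are both modest, and both alter the outer ring that carries the sulfamoylamino group rather than the shared core. Compound 4 `NC(=O)c1c(Oc2cccc(NS(N)(=O)=O)c2)cc(F)c(F)c1Nc1ccc(I)cc1F` differs from compound 1 by fluoro in place of hydrogen on an aromatic carbon, the place being ortho to the (2-fluoro-4-iodophenyl)amino group, ortho to a fluoro group, meta to a carbamoyl group and para to a large group. Going by the values given here, no measured step touches this part of the core, so the two known steps offer no direct guide; with both of them modest, nothing points to a large step here, in either direction. For compound 4 the expected step is a 1.2-fold lower number from compound 1 to compound 4 (0.08 log units; within the scatter), within or close to the scatter. Compound 4 is therefore estimated at 150 nM in this assay, with a range from 60 nM to 450 nM.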

Compound 4, half-maximal inhibitory concentration: 50 nM
Compound 4: middle estimate off by 3.0-fold (0.48 log units), on the high side, and the stated range ends above it.
By their numbers in this assay, from the lowest: compounds 4 and 2 (each within the scatter of the next); then compound 1; then compound 3.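

In this assay, the aromatic carbon ortho to a (2-fluoro-4-iodophenyl)amino group and ortho to a fluoro group turns out to be sensitive to substitution: fluoro in place of hydrogen gives a 3.6-fold lower number from compound 1 to compound 4 (0.56 log units; beyond the scatter), beyond the scatter. For the compounds shown here, the earlier steps both lay on the outer ring carrying the sulfamoylamino group, so this is the first sign that the shared core also moves the number, and a single added heavy atom is enough. Nothing measured here accounts for the step.

The compounds shown leave open whether chloro, methyl or methoxy on this carbon would give a similar step, or whether it is particular to fluoro. They also leave open how this fluoro would behave alongside the chloro of compound 2 in a single compound.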